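A few compounds are considered here, and "the series" means these few. Any claim that something is new, unique, unknown or untested is made for them only; others in the source may bear on it.

Measured in a functional assay on HeLa cells (Homo sapiens) for cytotoxicity, read by ELISA, with a stated time of 2 days (a higher number here means a weaker inhibitor, a lower number a stronger inhibitor), so far:
- compound 1 `Oc1cccc(-c2cc(-c3ccccc3)nc(-c3ccccc3)c2)c1` gives 15100 nM
- compound 2 `Oc1cccc(-c2cc(-c3ccccc3)nc(-c3ccsc3)c2)c1` gives 14900 nM
- compound 3 `Oc1cccc(-c2cc(-c3ccccc3)nc(-c3ccccn3)c2)c1` gives 29800 nM

The three values lie within the scatter of each other, so compound 3 (29800 nM) cannot be ranked against the other two.

The next structure is compound 4 `Oc1cccc(-c2cc(-c3ccccc3)nc(-c3cccnc3)c2)c1` with pyridin-3-yl in place of pyridin-2-yl on an aromatic carbon, next to the ring nitrogen (pyridin-3-yl in place of pyridin-2-yl on an aromatic carbon).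

Going by the values given here, three measured steps bear on this change, each an exchange of the aromatic group at that same place (a 1.0-fold lower number from compound 1 to compound 2 (0.01 log units; within the scatter)), (a 2.0-fold higher number from compound 1 to compound 3 (0.30 log units; within the scatter)) and (a 2.0-fold higher number from compound 2 to compound 3 (0.30 log units; within the scatter)). All three stay within the scatter. Among the compounds with values here, no measured compound carries pyridin-3-yl, so there is no direct reading of this group, and the expectation rests on these steps alone.

No step beyond the scatter is therefore expected in this assay and no direction can be assigned with any confidence. The estimated step is small (a 1.5-fold lower number from compound 3 to compound 4 (0.17 log units; within the scatter)).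

Compound 4 is expected at 20000 nM within an estimated range (10000 nM to 40000 nM).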

Compound 4, half-maximal inhibitory concentration: 17500 nM
The estimate for compound 4 lay 1.1-fold (0.06 log units) above the measured number, and the stated range covers the measured number.
By their numbers in this assay, from the lowest: compounds 2, 1, 4 and 3 (each within the scatter of the next).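

In this assay, pyridin-3-yl in place of pyridin-2-yl on this aromatic carbon, next to the ring nitrogen, keeps the same atoms and gives no readable change (a 1.7-fold lower number from compound 3 to compound 4 (0.23 log units; within the scatter)). The steps to the other two groups also stay within the scatter (a 1.2-fold higher number from compound 1 to compound 4 (0.06 log units; within the scatter)) and (a 1.2-fold higher number from compound 2 to compound 4 (0.07 log units; within the scatter)), so phenyl, thiophen-3-yl, pyridin-2-yl and pyridin-3-yl cannot be told apart at this position in this read-out, and the place of the nitrogen in the pyridine ring shows no measurable effect on the number. No measurement at hand offers an explanation for this flat picture.

Still open, going by these compounds, is whether any group on this carbon can move the number beyond the scatter, as only aromatic rings of similar size appear here, and a carboxylic acid, an amine or a longer alkyl chain at this place would be a sharper test. Going by these compounds alone, also open is what the 3-hydroxyphenyl and phenyl groups contribute, since both are common to all four compounds and no compound shows, for instance, a methoxy group in place of the hydroxyl.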